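Swapping Methoxy for Methylsulfanyl in a Cytotoxicity Series

The source may hold more compounds than are shown below. What is called first, only, known or untested is meant among the compounds shown, and "the series" means these compounds.

In a functional assay on NCI-H727 cells (Homo sapiens) for cytotoxicity, with a stated time of 48 h (on this read-out higher numbers stand for weaker inhibition and lower numbers for stronger inhibition), compound 1 `COc1cc(O)c(C(=O)/C=C/c2ccc(F)cc2)c(OC)c1` gives > 20000 nM, which is a limit of the assay and not a number. Within the data shown here, compound 2 `COc1cc(OC)c(C(=O)/C=C/c2ccccc2OC)c(OC)c1` gives 4000 nM, the only true number so far. Compound 3 `COc1cc(OC)c(C(=O)/C=C/c2ccccc2SC)c(OC)c1` carries methylsulfanyl in place of methoxy on an aromatic carbon, ortho to a large group (methylsulfanyl in place of methoxy on an aromatic carbon). Among the measured compounds shown here, no measured step covers this swap, so no shift beyond the scatter is expected in this assay. The expected change is a 1.1-fold higher number from compound 2 to compound 3 (0.05 log units; within the scatter). Compound 3 is estimated at 4500 nM, with an expected range of 1800 nM to 12000 nM.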

Compound 3, half-maximal inhibitory concentration: 8700 nM
The estimate for compound 3 lay 1.9-fold (0.29 log units) below the measured number; measured number inside the range.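

In this assay methylsulfanyl in place of methoxy on an aromatic carbon, ortho to a large group, gives a 2.2-fold higher number from compound 2 to compound 3 (0.34 log units; beyond the scatter) and so weaker inhibition, which shows that this position responds to the swap. The earlier compounds shown here offered no such reading, as compound 1 differs from compound 2 in more than one place and holds only a limit of the assay. From the compounds shown here alone, whether an amine or a longer chain such as ethoxy at this place would move the number further remains open. Nothing measured here bears on why the number moved.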